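The source may report more compounds than this note shows. Statements on the series, on what has been measured and on what is new or still open speak of the compounds shown alone.

In a functional assay on the whole organism (strain Wistar) for inhibition, with Rattus norvegicus as the target, with a stated time of 5 days, at a dose of 50 mg/kg by the oral route (a higher number here means more inhibition at the dose given (going by the name of the read-out), a lower number less inhibition), compound 1 `COc1ccc2cc(CCC(C)OC(C)=O)ccc2c1` gives 38%. Compound 2 `CC(=O)CCc1ccc2cc(OC(C)=O)ccc2c1` gives 2% in this assay, the lower of the two numbers, and its gap to compound 1 lies beyond the usual scatter. Compound 3 `CC(=O)CCc1ccc2cc(C)ccc2c1` has not yet been measured. It differs from compound 2 in a single place: methyl in place of acetoxy on an aromatic carbon. Among the measured compounds shown here, no measured pair shows this change, so its effect is unknown, and a step that stays within the scatter, in either direction, seems most likely. The estimated step from compound 2 to compound 3 is a number 8 percentage points higher from compound 2 to compound 3 (within the scatter). Compound 3 is therefore expected to give about 10% in this assay, somewhere between 0% and 30%.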

Compound 3, a percentage reported as inhibition, in the whole organism at one dose (the size of the read-out at that dose, not a potency): 34%
The estimate for compound 3 lay 24 percentage points below the measured number; measured number above the stated range.
By their numbers in this assay, from the lowest: compound 2; then compounds 3 and 1 (each within the scatter of the next).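

In this assay, among the compounds shown here, replacing acetoxy with methyl on this aromatic carbon gives a number 32 percentage points higher from compound 2 to compound 3 (beyond the scatter) and provides the first single-change comparison in this set. The group at this position therefore matters, but this one pair cannot show which difference counts, whether the loss of the carbonyl and ester oxygens or the smaller group. Nothing measured here explains the rise. Going by these compounds, it remains open whether an ethyl group, a chlorine atom or an amine at the same carbon would match methyl, and whether the effect would carry over to other side chains.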